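The source may hold more compounds than are shown below. What is called first, only, known or untested is meant among the compounds shown, and "the series" means these compounds.

Measured so far:
compound 1, `Cc1nn(C)cc1OCC1(c2ccccc2)CC1C(=O)Nc1ccc(C#N)cn1`: 204 nM
compound 2, `CCn1cc(OC[C@]2(c3ccccc3)C[C@@H]2C(=O)Nc2ccc(C#N)cn2)c(C)n1`: > 2000 nM

In an assay on isolated protein for binding affinity to Orexin receptor type 2 (Homo sapiens), read by radioligand binding (a lower number here means a stronger inhibitor, a higher number a weaker inhibitor), compound 1 gives 204 nM. Compound 2 gives > 2000 nM, which is a limit of the assay rather than a number; it is the limit of > 2000 nM in this assay, at which 1 of the 2 values shown sits. So compound 2 stands only at a limit, with no measured number of its own. For the measured compounds named here, compound 3, `CCn1cc(OC[C@@]2(c3ccccc3)C[C@H]2C(=O)Nc2ccc(C#N)cn2)c(C)n1`, has not yet been measured. the two compounds have the same atoms and bonds and differ only in configuration as drawn: 2 of 2 stereo elements differ (all stereocentres are inverted: mirror images); a stereocentre at a saturated ring carbon is drawn R in compound 2 and S in compound 3; a stereocentre at a saturated ring carbon is drawn S in compound 2 and R in compound 3 The move from compound 2 to compound 3 is thus a change of handedness alone, and no measured pair here shows what such a change does. Compound 1 differs from compound 2 in more than one place, so its value gives only loose guidance. Because compound 1 gives 204 nM with a closely related structure, compound 3 is expected to bind more strongly than its mirror image, by an at least 20-fold lower number from compound 2 to compound 3 (1.30 log units; beyond the scatter). Compound 3 is estimated at 100 nM, within 35 nM to 350 nM.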

Compound 3, inhibition constant: 8 nM
Compound 3: middle estimate off by 13-fold (1.10 log units), on the high side; the whole stated range lies above it.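

Compound 2 stands at a limit of the assay and not at a number: the limit of > 2000 nM in this assay, at which 1 of the 3 values shown sits. In this assay, for the compounds shown here, the earlier compounds left the role of handedness unknown, and this pair now gives an at least 250-fold lower number from compound 2 to compound 3 (2.39 log units; beyond the scatter), so the arrangement at the two ring stereocentres matters greatly for binding to this receptor. This large step can be assigned to configuration alone because no atom or bond changes: the fact that compounds 2 and 3 differ only in the configuration as drawn.

On these data alone, the true size of the step stays open: compound 2 has no number of its own, so the gap could be larger than the printed bound. Only this one pair of mirror images is shown, so it also stays open whether the same hand is preferred when the nitrile gives way to another group, such as a carboxylic acid or an amine.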